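Swapping 1H-pyrazol-4-yl for pyridin-4-yl on a shared core

The compounds below may be only part of what the source reports. "The series", "measured", "known", "first", "only" and "open" are said of these compounds alone.

Two compounds have so far been taken into a functional assay on NCI-H1993 cells (Homo sapiens) for inhibition, read by CCK-8 assay, with a stated time of 72 h; on this read-out higher numbers stand for weaker inhibition and lower numbers for stronger inhibition. For compound 1 `CCC(c1ccc2ncccc2c1F)n1cnc2ncc(-c3ccc(C(=O)OC)c(F)c3)nc21` the entry reads "not determined" (no result reported), so it offers no comparison. Going by the values given here, compound 2 `c1cnc2ccc(Cn3cnc4ncc(-c5cn[nH]c5)nc43)cc2c1` gives 2890 nM, the only number available, so it cannot yet be ranked against anything else in this set. Compound 3 `c1cnc2ccc(Cn3cnc4ncc(-c5ccncc5)nc43)cc2c1` keeps the core of compound 2 and changes one group, with pyridin-4-yl in place of 1H-pyrazol-4-yl on an aromatic carbon. Among the compounds with values here, no measured pair here differs in just one place, so the data give no direct guide to the size of this change. The expectation is therefore a step within the usual scatter, with no firm direction, and the estimated shift is a 1.2-fold lower number from compound 2 to compound 3 (0.06 log units; within the scatter). For compound 3 the expected value is 2500 nM, within a range of 600 nM to 10000 nM.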

Compound 3, half-maximal inhibitory concentration: 1160 nM
The estimate for compound 3 lay 2.2-fold (0.33 log units) above the measured number; low and high end bracket the measured number.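

In this assay, going by these compounds alone, placing pyridin-4-yl in position of 1H-pyrazol-4-yl gives a 2.5-fold lower number from compound 2 to compound 3 (0.40 log units; beyond the scatter), the first measured evidence that the read-out responds to the ring at this site. Compound 3 has no hydrogen-bond donor on this ring and still inhibits more strongly, so a donor there is not required for inhibition at this level. The change alters ring size and atom make-up together, so this single pair cannot separate their contributions, and no supporting data point to a cause.

The compounds shown leave open whether the same step would appear on a different core. They also leave open how an amine, a carboxylic acid or a short alkyl chain would compare with these two aromatic rings at this site.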